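A few compounds are considered here, and "the series" means these few. Any claim that something is new, unique, unknown or untested is made for them only; others in the source may bear on it.

Working notes on the series. The three measured compounds share one core and differ only in the group on the outer six-membered ring. Compound 1 `N=C(N)c1ccc(-c2ccc(-c3ccc(Cl)cc3)s2)s1` gives 49% in an ADME assay on cells (Erythrocyte, Homo sapiens) for activation, read by hemolysis, with a stated time of 30 min, tested at 5 mM; a higher number here means a stronger effect of the compound at the concentration tested, a lower number a weaker effect. Compound 2 `N=C(N)c1ccc(-c2ccc(-c3ccccc3)s2)s1` gives 56.7% in this assay. Compound 3 `N=C(N)c1ccc(-c2ccc(-c3ccc(F)cc3)s2)s1` gives 59.7% in this assay. Compound 3 thus has the highest of the three numbers, though only its gap to compound 1 is beyond the scatter (a number 10.7 percentage points higher from compound 1 to compound 3 (beyond the scatter)), while the gap to compound 2 is within it (a number 3 percentage points higher from compound 2 to compound 3 (within the scatter)); the remaining step, a number 7.7 percentage points higher from compound 1 to compound 2 (within the scatter), is also within the scatter.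

Compound 4 `COc1ccc(-c2ccc(-c3ccc(C(=N)N)s3)s2)cc1` differs from compound 3 by methoxy in place of fluoro on an aromatic carbon. Among the compounds with values here, no measured step brings in a methoxy at this place; the steps that bear on it are the three exchanges of chloro, hydrogen and fluoro at the same place, all of which are small, with only one modest step beyond the scatter. A step of similar size is therefore expected in this assay, from compound 3 to compound 4 of a number 2.7 percentage points lower from compound 3 to compound 4 (within the scatter), in no clear direction and likely within the scatter. Compound 4 is estimated at 57%, with a range from 42% to 72%.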

Compound 4, a percentage reported as activity, at one concentration (the size of the read-out at that concentration, not a potency): 63.7%
For compound 4 the middle estimate is 6.7 percentage points below the measured one; the measured number falls inside the stated range.
By their numbers in this assay, from the lowest: compounds 1, 2, 3 and 4 (each within the scatter of the next, the first and the last beyond it).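

Methoxy, with two heavy atoms and one hydrogen-bond acceptor where fluoro has one heavy atom and none, leaves the read-out in this assay within the scatter of the fluoro compound (a number 4 percentage points higher from compound 3 to compound 4 (within the scatter)) and of the unsubstituted one (a number 7 percentage points higher from compound 2 to compound 4 (within the scatter)). Only the exchange against chloro goes beyond the scatter (a number 14.7 percentage points higher from compound 1 to compound 4 (beyond the scatter)), so at this place compound 1 is set apart from compound 3 and compound 4, but not from compound 2. No measurement at hand accounts for these steps.

Still open, on these data alone, is whether an amine, a carboxylic acid or a longer chain such as ethoxy at this place would stay within the scatter of compound 4. Also open, as far as these compounds go, is whether methoxy elsewhere on the outer ring would give a similar number.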